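Working notes: trifluoromethyl in place of hydroxy on compound 3

The source may hold more compounds than are shown below. What is called first, only, known or untested is meant among the compounds shown, and "the series" means these compounds.

Compound 3 `O=C(O)c1ccc(-c2cnc(C(=O)CCCCCCc3ccccc3)o2)cc1` gives 60 nM in an assay (Rattus norvegicus) for inhibition of Fatty-acid amide hydrolase 1 (Homo sapiens) (on this read-out higher numbers stand for weaker inhibition and lower numbers for stronger inhibition), and stands second highest of the three numbers measured. Its nearest neighbour is compound 1 `O=C(CCCCCCc1ccccc1)c1ncc(-c2ccccc2F)o1` at 110 nM, the gap being a 1.8-fold lower number from compound 1 to compound 3 (0.26 log units; within the scatter). Compound 2 `Nc1cccc(-c2cnc(C(=O)CCCCCCc3ccccc3)o2)c1` gives 19 nM, and the step of a 3.2-fold higher number from compound 2 to compound 3 (0.50 log units; beyond the scatter) lies beyond the scatter, as does a 5.8-fold lower number from compound 1 to compound 2 (0.76 log units; beyond the scatter).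

Compound 4 `O=C(CCCCCCc1ccccc1)c1ncc(-c2ccc(C(=O)C(F)(F)F)cc2)o1` differs from compound 3 by trifluoromethyl in place of hydroxy on a carbonyl carbon. Among the compounds with values here, none of the measured steps alters this carbonyl carbon; each swaps the whole substituent on the aromatic carbon, and their sizes, modest at most, suggest that changes at this end of the molecule move this assay by small amounts. Within the data shown here, with no closer precedent, a step within the scatter is the working expectation, the range kept wide to allow a modest shift either way.

Compound 4 is therefore expected at 45 nM, with a range from 12 nM to 170 nM, which corresponds to an expected 1.3-fold lower number from compound 3 to compound 4 (0.12 log units; within the scatter).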

Compound 4, inhibition constant: 65 nM
Beside the measured number, compound 4's estimate is 1.4-fold (0.16 log units) below it, and the stated range covers the measured number.
By their numbers in this assay, from the lowest: compound 2; then compounds 3, 4 and 1 (each within the scatter of the next).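

In this assay, within the data shown here, trifluoromethyl in place of hydroxy on a carbonyl carbon gives a 1.1-fold higher number from compound 3 to compound 4 (0.03 log units; within the scatter), and this is the only measured step that alters this carbonyl carbon while leaving the rest of the substituent on the aromatic carbon in place. In this pair, the hydroxy with its hydrogen-bond donor can leave and trifluoromethyl, with no such donor and more heavy atoms, can enter without a step beyond the scatter. Nothing at hand explains why the two groups read alike.

As far as these compounds go, it remains open whether an amine, a methyl or a methoxy on this carbonyl carbon would also stay within the scatter of these two compounds. Also open, from the compounds shown here alone, is whether the carbonyl is needed at all, a question that a nitrile in place of the whole carboxy group would address.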